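A few compounds are considered here, and "the series" means these few. Any claim that something is new, unique, unknown or untested is made for them only; others in the source may bear on it.

Compound 3, `CNC(=O)/C=C/c1ccncc1-c1ccc2ccccc2c1`, is the only one of the three measured compounds that gives an actual number in a functional assay on MCF7 cells (Homo sapiens) for inhibition, read by sulforhodamine B assay, with a stated time of 72 h; on this read-out lower numbers stand for stronger inhibition of growth and higher numbers for weaker inhibition of growth: compound 3 reaches 9340 nM. Compound 1, `CNC(=O)CCc1ccncc1-c1ccc2ccccc2c1`, gives in this assay > 10000 nM, which is a limit of the assay and not a number. Compound 2, `O=C(O)CCc1ccncc1-c1ccc2ccccc2c1`, likewise gives in this assay > 10000 nM, again a limit. Both limits sit at the limit of > 10000 nM in this assay, at which 2 of the 3 values shown sit. Because of this the step that the two limits leave unreadable from compound 1 to compound 2 cannot be sized, and the steps of an at least 1.0-fold lower number from compound 1 to compound 3 (0.02 log units; that floor lies within the scatter) and an at least 1.0-fold lower number from compound 2 to compound 3 (0.02 log units; that floor lies within the scatter) carry only a floor that lies within the scatter, so compound 3 cannot be called more potent than the other two.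

Compound 4, `O=C(/C=C/c1ccncc1-c1ccc2ccccc2c1)NC1CC1`, differs from compound 3 in one place: cyclopropyl in place of methyl on an amide-type nitrogen. Going by the values given here, no measured step alters the group on the amide-type nitrogen, so none bears directly on this change; the closest one, from compound 1 to compound 2, touches the carbonyl carbon instead and is unreadable. The expectation is therefore a step of no size beyond the scatter, a 1.2-fold lower number from compound 3 to compound 4 (0.07 log units; within the scatter), in this assay. Compound 4 is accordingly estimated at 8000 nM, with a range from 3000 nM to 25000 nM, and a fair chance that only a limit is reported.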

Compound 4, concentration for 50% growth inhibition: 6840 nM
Beside the measured number, compound 4's estimate is 1.2-fold (0.07 log units) above it, and the stated range covers the measured number.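

In this assay, going by these compounds alone, the change on the amide-type nitrogen can be read for the first time: swapping methyl for cyclopropyl gives a 1.4-fold lower number from compound 3 to compound 4 (0.14 log units; within the scatter). This position therefore takes the larger group, with its three-membered ring of carbon only, without any shift beyond the scatter, and compound 3 and compound 4 cannot be put in order. Set against the two compounds that stop at a limit, compound 4 shows only an at least 1.4-fold lower number from compound 2 to compound 4 (0.16 log units; that floor lies within the scatter) and an at least 1.4-fold lower number from compound 1 to compound 4 (0.16 log units; that floor lies within the scatter), and neither floor can be sized further because both of those compounds give a limit and not a number: the limit of > 10000 nM in this assay, at which 2 of the 4 values shown sit.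

Going by these compounds, what a very different group on this nitrogen would do remains open, whether a plain hydrogen, a tert-butyl, a benzyl or a chain ending in an amine, and any of these might or might not move the number beyond the scatter. Also open, on these data alone, is whether the 2-(cyclopropylcarbamoyl)ethenyl chain could be paired with other groups on the shared core to give a step that can be sized.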